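A Second Chloro on the Sulfonyl Aryl of Compound 3

The compounds below may be only part of what the source reports. "The series", "measured", "known", "first", "only" and "open" are said of these compounds alone.

Compound 3 `O=C(/C=C/c1cccc(NS(=O)(=O)c2cccc(Cl)c2)c1)c1nc2ccccc2[nH]1` gives 737 nM in a functional assay on HCT-116 cells (Homo sapiens) for antiproliferative activity, read by MTT assay, with a stated time of 48 h (a higher number here means a weaker inhibitor, a lower number a stronger inhibitor), the lowest of the three numbers measured. Compound 1 `O=C(Nc1cccc(/C=C/C(=O)c2nc3ccccc3[nH]2)c1)c1ccc(Br)cc1` gives 2230 nM and compound 2 `Cc1cc(C)cc(C(=O)Nc2cccc(/C=C/C(=O)c3nc4ccccc4[nH]3)c2)c1` gives 1550 nM; the steps of a 3.0-fold lower number from compound 1 to compound 3 (0.48 log units; beyond the scatter) and a 2.1-fold lower number from compound 2 to compound 3 (0.32 log units; beyond the scatter) both lie beyond the scatter, while a 1.4-fold lower number from compound 1 to compound 2 (0.16 log units; within the scatter) does not. Compound 4 `O=C(/C=C/c1cccc(NS(=O)(=O)c2cc(Cl)cc(Cl)c2)c1)c1nc2ccccc2[nH]1` differs from compound 3 by chloro in place of hydrogen on an aromatic carbon, the aryl on the sulfonyl reading 3-chlorophenyl to 3,5-dichlorophenyl. Going by the values given here, no measured step alters the substitution of that aryl; the only change of aryl substituents, between compound 1 and compound 2, sits on the carbonyl and stayed within the scatter. The expected step of a 1.2-fold lower number from compound 3 to compound 4 (0.09 log units; within the scatter) is therefore small, in no sure direction. Compound 4 is estimated at 600 nM, with a range from 250 nM to 1500 nM.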

Compound 4, half-maximal inhibitory concentration: 2840 nM
Compound 4: middle estimate off by 4.7-fold (0.68 log units), on the low side; measured number above the stated range.
By their numbers in this assay, from the lowest: compound 3; then compounds 2, 1 and 4 (each within the scatter of the next).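

In this assay the aryl on the sulfonyl proves sensitive to substitution: 3-chlorophenyl to 3,5-dichlorophenyl gives a 3.9-fold higher number from compound 3 to compound 4 (0.59 log units; beyond the scatter), a step beyond the scatter. Going by these compounds alone, one added chlorine here thus moves the number further than the one earlier change of aryl substituents, on the carbonyl, a 1.4-fold lower number from compound 1 to compound 2 (0.16 log units; within the scatter), which stayed within the scatter. Nothing measured here gives a reason for this rise.

The compounds shown leave open whether a methyl, a methoxy or an amine in place of this second chloro would raise the number as well, or leave it near that of compound 3.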